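The source may report more compounds than this note shows. Statements on the series, on what has been measured and on what is new or still open speak of the compounds shown alone.

In a functional assay on A-375 cells (Homo sapiens) for antiproliferative activity (on this read-out higher numbers stand for weaker inhibition and lower numbers for stronger inhibition), compound 1 `O=C(Nc1ccc(-c2cscn2)cc1)C1CCCN(Cc2ccc(F)c(F)c2)C1` gives 880 nM, compound 2 `O=C(Nc1ccc(-c2cscn2)cc1)C1CCCN(Cc2cc(F)c(F)c(F)c2)C1` gives 400 nM and compound 3 `O=C(Nc1ccc(-c2ccncc2)cc1)C1CCCN(Cc2ccc(F)c(F)c2)C1` gives 600 nM. Compound 3 thus holds the middle of the three numbers, within the scatter of both others. Compound 4 `O=C(Nc1ccc(-c2ccccn2)cc1)C1CCCN(Cc2ccc(F)c(F)c2)C1` has pyridin-2-yl in place of pyridin-4-yl on an aromatic carbon. The closest evidence is a 1.5-fold lower number from compound 1 to compound 3 (0.17 log units; within the scatter), an exchange of 1,3-thiazol-4-yl for pyridin-4-yl that stays within the scatter. The other measured step, a 2.2-fold lower number from compound 1 to compound 2 (0.34 log units; beyond the scatter), is modest but concerns fluoro in place of hydrogen, so it says little here. No two pyridinyl isomers have yet been compared. The expected step is a 1.1-fold higher number from compound 3 to compound 4 (0.03 log units; within the scatter), none beyond the scatter. For compound 4 the estimate is 650 nM, with an expected range of 280 nM to 1500 nM.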

Compound 4, half-maximal inhibitory concentration: 9000 nM
Estimate against measurement, compound 4: 14-fold (1.14 log units) below; the whole stated range lies below it.
By their numbers in this assay, from the lowest: compounds 2, 3 and 1 (each within the scatter of the next, the first and the last beyond it); then compound 4.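

Exchanging pyridin-4-yl for pyridin-2-yl, the same atoms joined differently, gives a 15-fold higher number from compound 3 to compound 4 (1.18 log units; beyond the scatter), so this position para to a large group tells the two pyridinyl isomers sharply apart. The exchange from 1,3-thiazol-4-yl is also large, at a 10-fold higher number from compound 1 to compound 4 (1.01 log units; beyond the scatter), although pyridin-4-yl and 1,3-thiazol-4-yl had stayed within the scatter of each other. Nothing measured here accounts for this loss of activity.

From the compounds shown here alone, whether pyridin-3-yl or plain phenyl at this position would track pyridin-4-yl or pyridin-2-yl remains open. So does whether the extra fluoro of compound 2 would alter the pyridin-2-yl result.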